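Swapping methoxy for ethyl on a weak inhibitor

The source may hold more compounds than are shown below. What is called first, only, known or untested is meant among the compounds shown, and "the series" means these compounds.

Of the compounds shown here, three sharing one core have been tested in a functional assay on cells (T-cell, Homo sapiens) for inhibition; a higher number here means a weaker inhibitor, a lower number a stronger inhibitor. Compound 1, `COc1ccc(-c2cnc3nc(N)nc(N4CCN(c5cc(Cl)cc(Cl)c5)CC4)c3n2)cc1OC`, gives 3400 nM in this assay. Compound 2, `CCOc1nc(N)nc2ncc(-c3ccc(OC)cc3)nc12`, reaches only the limit of this assay, > 10000 nM. Compound 3, `COc1ccc(-c2cnc3nc(N)nc(OC(C)C)c3n2)cc1`, also reaches only the limit, > 10000 nM. Within the data shown here, the single one-place step among them runs a step that the two limits leave unreadable from compound 2 to compound 3. Both of its ends are limits, and its size therefore cannot be read. the limit of > 10000 nM in this assay, at which 2 of the 3 values shown sit, shows how little the measured numbers pin down.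

Compound 4, `CCOc1nc(N)nc2ncc(-c3ccc(CC)cc3)nc12`, differs from compound 2 by ethyl in place of methoxy on an aromatic carbon. No measured step covers a change of this kind, so nothing shown speaks to its direction or size. With compound 2 at the limit and compound 3 at the limit as well, the plain expectation is that compound 4 stays in the same region, most likely again as a limit. Compound 4 is estimated at 10000 nM, between 4000 nM and 30000 nM, which means an expected step of a number no higher from compound 2 to compound 4 (the limit leaves the size open).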

Compound 4, half-maximal inhibitory concentration: 8200 nM
Beside the measured number, compound 4's estimate is 1.2-fold (0.09 log units) above it, and the stated range covers the measured number.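

In this assay, ethyl in place of methoxy on an aromatic carbon, para to a large group, gives an at least 1.2-fold lower number from compound 2 to compound 4 (0.08 log units; that floor lies within the scatter). Among these compounds, compound 2 gives > 10000 nM, which is a limit, so that step is only a floor, and the one value at this change that is a true number is what sets it: the limit of > 10000 nM in this assay, at which 2 of the 4 values shown sit. Compound 4 gives 8200 nM, a measured number, which shows that at this position the swap to ethyl, with no hydrogen-bond acceptor where methoxy has one, does not push the compound out of the readable range.

On these data alone, how far compound 4 really lies from compound 2 stays open, and the step from compound 2 to compound 3 cannot be read. A longer chain such as propyl or a carboxylic acid at this place on the ring would show whether the readable value holds for other groups.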